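Ring Size at the Thiocarbonyl and Growth Inhibition

A few compounds are considered here, and "the series" means these few. Any claim that something is new, unique, unknown or untested is made for them only; others in the source may bear on it.

Three related thiosemicarbazide-type compounds have been tested in a functional assay on A-431 cells (Homo sapiens) for cytotoxicity, read by MTT assay, with a stated time of 72 h, tested at 1 uM; on this read-out higher numbers stand for more inhibition of growth at the one concentration tested and lower numbers for less inhibition of growth. Compound 1 `Cc1cccc(/C(N)=N/NC(=S)N2CCCCC2)n1` gives 35%. Compound 2 `Cc1cccc(/C(N)=N/NC(=S)N2CCCC2)n1` carries the change pyrrolidin-1-yl in place of piperidin-1-yl on a thiocarbonyl carbon and gives 21%, so the step of a number 14 percentage points lower from compound 1 to compound 2 (beyond the scatter) is a modest loss. Compound 3 `Cc1ccnc(/C(N)=N/NC(=S)N2CCCCC2)c1` shares the same atoms as compound 1, joined differently; how the two cores differ is not broken down here. Compound 3 gives 31.1%, which lies within the usual scatter of the value of compound 1.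

Compound 4 `Cc1ccnc(/C(N)=N/NC(=S)N2CCCC2)c1` is not yet measured. It differs from compound 3 by pyrrolidin-1-yl in place of piperidin-1-yl on a thiocarbonyl carbon, the same change that was made from compound 1 to compound 2, and at the same kind of place. The expectation for compound 4 therefore rests on that single earlier step: because a number 14 percentage points lower from compound 1 to compound 2 (beyond the scatter) was a modest loss, a step of a number 14.1 percentage points lower from compound 3 to compound 4 (beyond the scatter) is expected from compound 3 to compound 4. Compound 4 is thus estimated to give 17%, with a likely range from 5% to 30%.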

Compound 4, percent growth inhibition at one concentration: 58.5%
Compound 4: the middle estimate sits 41.5 percentage points below what was measured; the measured number lies above the stated range.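

In this assay, the change to pyrrolidin-1-yl on the thiocarbonyl carbon gives a number 27.4 percentage points higher from compound 3 to compound 4 (beyond the scatter), so the same swap does not carry over with the same result from one core to the other: the same change on two cores in this assay, a number 14 percentage points lower (beyond the scatter) from compound 1 to compound 2 and a number 27.4 percentage points higher (beyond the scatter) from compound 3 to compound 4, 41.4 percentage points apart, beyond the scatter of two such steps

For these four compounds, then, the outcome of this ring change depends on the core it is made on, and a step seen on one core cannot simply be added to a compound with the other core. This does not show why the two cores respond differently, and two steps, each read at a single concentration, cannot say which direction a third core would follow.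

The compounds shown leave open what a morpholin-4-yl ring, an azepan-1-yl ring or an open-chain dimethylamino group on the thiocarbonyl carbon would do on either core. As far as these compounds go, it also remains open whether the higher number of compound 4 would hold at other concentrations or in other cells.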